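A few compounds are considered here, and "the series" means these few. Any claim that something is new, unique, unknown or untested is made for them only; others in the source may bear on it.

In an ADME assay on MCF7 cells (Homo sapiens) for cytotoxicity, read by MTT assay, with a stated time of 72 h (on this read-out higher numbers stand for weaker inhibition of growth and lower numbers for stronger inhibition of growth), compound 1 (`C=CCNC(=O)C1C(C(=O)O)[C@@H]2CC[C@H]1O2`) gives 10000 nM and compound 2 (`CCCCNC(=O)C1C(C(=O)O)[C@@H]2CC[C@H]1O2`) gives 10000 nM, so compound 2 stands level with compound 1. Compound 3 (`O=C(O)C1C(C(=O)NCCCc2ccccc2)[C@H]2CC[C@@H]1O2`) differs from compound 2 by phenyl in place of methyl on a saturated chain carbon, three bonds along the chain from an amide-type nitrogen. Among the measured compounds shown here, the only measured step, no change at the digits printed from compound 1 to compound 2 (within the scatter), stays within the scatter, and no measured compound carries a phenyl. Nothing beyond the scatter is therefore expected in this assay, and the estimated step is no change at the digits printed from compound 2 to compound 3 (within the scatter). Compound 3 is expected at 10000 nM, within a range of 4000 nM to 20000 nM.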

Compound 3, concentration for 50% growth inhibition: 10000 nM
Beside the measured number, compound 3's estimate shows no gap at the digits printed; the measured number falls inside the stated range.
By their numbers in this assay, from the lowest: compounds 1, 2 and 3 (each within the scatter of the next).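

In this assay the step reads no change at the digits printed from compound 2 to compound 3 (within the scatter). The earlier pair had shown only propyl in place of vinyl at the chain; phenyl in place of methyl on a saturated chain carbon, three bonds along the chain from an amide-type nitrogen, now shows that a six-membered aromatic ring also leaves the number within the scatter. Nothing available explains this result.

As far as these compounds go, whether an amine or a carboxylic acid in place of the phenyl would shift the number remains open. So does the effect of a longer chain carrying the phenyl.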